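The source may hold more compounds than are shown below. What is called first, only, known or untested is meant among the compounds shown, and "the series" means these compounds.

Compound 1 `Cc1c(CO)c(CO)c2n1[C@@H](c1ccccc1)SC2` gives 1900 nM in a functional assay on MCF7 cells (Homo sapiens) for cytotoxicity, read by MTT assay, with a stated time of 48 h; a lower number here means a stronger inhibitor, a higher number a weaker inhibitor.
Compound 2 `Cc1c(CO)c(CO)c2n1CSC2` gives 38100 nM in this assay.

Among the measured compounds shown here, of the two measured compounds, compound 1 gives the lower number in this assay; the single step between them, a 20-fold higher number from compound 1 to compound 2 (1.30 log units; beyond the scatter), is a large one. Compound 3 `OCc1cn2c(c1CO)CS[C@@H]2c1ccccc1` differs from compound 1 in another part of the shared core: hydrogen in place of methyl on an aromatic carbon. For the measured compounds named here, no measured step touches this position, and the only step known, hydrogen in place of phenyl on a saturated ring carbon, is of a different kind, so it offers no direct guide. Removing the methyl group is a smaller alteration than removing the phenyl; a modest shift toward a higher number seems the likeliest outcome, though a result within the scatter cannot be excluded. Compound 3 is therefore expected at 3500 nM, with a range from 1200 nM to 10000 nM, which corresponds to an expected step of a 1.8-fold higher number from compound 1 to compound 3 (0.27 log units; within the scatter).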

Compound 3, half-maximal inhibitory concentration: 19400 nM
Compound 3: the middle estimate sits 5.5-fold (0.74 log units) below what was measured, and the stated range ends below it.
By their numbers in this assay, from the lowest: compound 1; then compounds 3 and 2 (each within the scatter of the next).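

Removing the methyl from this aromatic carbon, next to the ring nitrogen, is a large change in this assay: there is a 10-fold higher number from compound 1 to compound 3 (1.01 log units; beyond the scatter). The earlier compounds shown here showed only the effect of the phenyl on a saturated ring carbon, with a 20-fold higher number from compound 1 to compound 2 (1.30 log units; beyond the scatter); this result shows that a second site on the shared core also affects the read-out. Here, the departure of one carbon atom is enough to produce a step beyond the scatter. Nothing available accounts for this step.

The compounds shown leave open whether a longer chain such as ethyl, or an amine, on this aromatic carbon would match the methyl of compound 1. They also leave open whether removing the methyl has the same size of effect without the phenyl.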